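Aniline swap on the shared core, acrylamide retained

The source may report more compounds than this note shows. Statements on the series, on what has been measured and on what is new or still open speak of the compounds shown alone.

Measured compounds:
compound 1 `O=C(CSc1nc(Nc2ccccc2)c2ccccc2n1)Nc1ccc(Cl)cc1Cl`: 8410 nM
compound 2 `C=CC(=O)Nc1cccc(NC(=O)CSc2nc(Nc3ccccc3Br)c3ccccc3n2)c1`: 19300 nM

In a functional assay on NCI-H1975 cells (Homo sapiens) for inhibition, read by MTT assay, with a stated time of 72 h (a higher number here means a weaker inhibitor, a lower number a stronger inhibitor), compound 2 gives 19300 nM, the highest of the two numbers; compound 1 gives 8410 nM, a lower number, and the gap lies beyond the scatter. Compound 3 `C=CC(=O)Nc1cccc(NC(=O)CSc2nc(Nc3ccc(Cl)c(Cl)c3)c3ccccc3n2)c1` is not yet measured. It differs from compound 2 by 3,4-dichlorophenyl in place of 2-bromophenyl on a nitrogen on an aromatic ring. Going by the values given here, with no measured pair sharing this change, the step of a 1.6-fold lower number from compound 2 to compound 3 (0.21 log units; within the scatter) is expected to be modest, toward a lower number, and may well stay within the scatter. Compound 3 is accordingly estimated at 12000 nM, within a range from 4000 nM to 36000 nM.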

Compound 3, half-maximal inhibitory concentration: 19100 nM
Compound 3: middle estimate off by 1.6-fold (0.20 log units), on the low side; low and high end bracket the measured number.
By their numbers in this assay, from the lowest: compound 1; then compounds 3 and 2 (each within the scatter of the next).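

The step of a 1.0-fold lower number from compound 2 to compound 3 (0.00 log units; within the scatter) shows that, in this assay, 3,4-dichlorophenyl and 2-bromophenyl on this nitrogen cannot be told apart, even though the two groups carry different halogens at different ring positions. With the acrylamide retained, this single change therefore leaves the read-out within the scatter. Nothing shown bears on why the two groups read alike. Going by these compounds, what a morpholine or a carboxylic acid on this phenyl ring would give remains open. So does the contribution of the acrylamide, as against a plain acetamide, on the other arm.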